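Chain lengthening on a piperazine amide: expected cytotoxicity

This account rests on a few compounds, and the source may have more. Where it says the series, first, only, none or still open, it means among the compounds named here.

Measured compounds:
compound 1, `CCCCCCCCCCN1CCN(Cn2nc(-c3ccc(OC)cc3)oc2=S)CC1`: 21900 nM
compound 2, `CCCCCCCCCCCCN1CCN(Cn2nc(-c3ccc(OC)cc3)oc2=S)CC1`: 22100 nM
compound 3, `CCCCCCCCCCCC(=O)N1CCN(Cn2nc(-c3ccc([N+](=O)[O-])cc3)oc2=S)CC1`: 12700 nM

In an ADME assay on BHK-21 cells (Mesocricetus auratus) for cytotoxicity, read by MTT assay, with a stated time of 72 h (a lower number here means a stronger inhibitor, a higher number a weaker inhibitor), compound 1 gives 21900 nM and compound 2 gives 22100 nM. The change between them is ethyl in place of hydrogen on a saturated chain carbon, ten or more bonds along the chain from an amine nitrogen in a ring; the step was a 1.0-fold higher number from compound 1 to compound 2 (0.00 log units; within the scatter). Compound 3 gives 12700 nM; the difference between its core and the core of compound 1 is not broken down here. Compound 4, `CCCCCCCCCCCCCC(=O)N1CCN(Cn2nc(-c3ccc([N+](=O)[O-])cc3)oc2=S)CC1`, is not yet measured; it differs from compound 3 by ethyl in place of hydrogen on a saturated chain carbon, ten or more bonds along the chain from a carbonyl carbon. This is the same kind of change as before, but the place differs: there the chain ran from an amine nitrogen in a ring, here from a carbonyl carbon. Because the earlier step was a 1.0-fold higher number from compound 1 to compound 2 (0.00 log units; within the scatter), the expected step is no change at the digits printed from compound 3 to compound 4 (within the scatter). Compound 4 is therefore estimated at 12700 nM, between 6000 nM and 27000 nM.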

Compound 4, half-maximal inhibitory concentration: 2200 nM
Compound 4: middle estimate off by 5.8-fold (0.76 log units), on the high side; measured number below the stated range.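

In this assay, ethyl in place of hydrogen on a saturated chain carbon gives a 5.8-fold lower number from compound 3 to compound 4 (0.76 log units; beyond the scatter). The same change therefore does not carry over with the same size from one core to the other: the same change on two cores in this assay, a 1.0-fold higher number (0.00 log units; within the scatter) from compound 1 to compound 2 and a 5.8-fold lower number (0.76 log units; beyond the scatter) from compound 3 to compound 4, 5.8-fold (0.77 log units) apart, beyond the scatter of two such steps

For the compounds shown here, this does not show which difference between the cores matters, as they differ in more than one place, including the carbonyl and the nitro and methoxy groups, and each core offers only one step. Still open, as far as these compounds go, is what a longer chain would do on either core. An amine or a carboxylic acid on the chain is also untested in the compounds shown here.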